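Propoxy to isopropoxy: branching the ether in the series

The source may report more compounds than this note shows. Statements on the series, on what has been measured and on what is new or still open speak of the compounds shown alone.

Working notes on a functional assay on corpus cavernosum (Rattus norvegicus) for activation; a lower number here means a smaller maximal response, a higher number a larger maximal response. Compound 1 `O=c1[nH]c(-c2ccccc2O)nc2c1cnn2-c1ccccc1` gives 93%. Within the data shown here, compound 2 `CCCOc1ccccc1-c1nc2c(cnn2-c2ccccc2)c(=O)[nH]1` gives 150%; this is the higher of the two values in hand, and the only step on record, a number 57 percentage points higher from compound 1 to compound 2 (beyond the scatter), is the one that separates compound 2 from compound 1.

Compound 3 `CC(C)Oc1ccccc1-c1nc2c(cnn2-c2ccccc2)c(=O)[nH]1` has not yet been measured. It differs from compound 2 by isopropyl in place of propyl on an oxygen on an aromatic ring; the two have the same atoms, joined differently. Among the measured compounds shown here, no measured step involves this exchange. For the measured compounds named here, the one step available, a number 57 percentage points higher from compound 1 to compound 2 (beyond the scatter), replaces hydrogen with propyl at the same oxygen and is large, but it speaks to the presence of the group there, not to its branching. Compound 3 keeps a group of that kind on the oxygen, so the maximal response is expected to stay near that of compound 2, with at most a modest step in this assay and no firm direction. The estimate for compound 3 is 140%, in the range 105% to 170%, which corresponds to an expected step of a number 10 percentage points lower from compound 2 to compound 3 (within the scatter).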

Compound 3, largest response reached (Emax), in percent of the reference or control that the assay uses: 130%
Compound 3: the middle estimate sits 10 percentage points above what was measured; the range from low to high includes it.
By their numbers in this assay, from the lowest: compound 1; then compound 3; then compound 2.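

Working notes on the ether position: in this assay this position responds to how the alkyl group is joined and not only to whether one is present, since exchanging propyl for isopropyl, with the same atoms joined differently, gives a modest step (a number 20 percentage points lower from compound 2 to compound 3 (beyond the scatter)). The gain over hydrogen on the oxygen survives branching, and the step remains large (a number 37 percentage points higher from compound 1 to compound 3 (beyond the scatter)), so among these three compounds both alkyl ethers stand clear of the compound with hydrogen there, with the unbranched propyl highest. Nothing available explains why the branched ether falls short of the unbranched one, and this order is a description of the values alone.

The compounds shown leave open how the response in this assay follows chain length and shape on this oxygen, for instance with methyl, ethyl or a longer chain such as butyl, and whether a cyclopropyl ring would fall nearer to propyl or to isopropyl. They also leave open what a chain ending in an amine or a carboxylic acid would do at the same place.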